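A New Aryl Group on the Shared Core

The source may report more compounds than this note shows. Statements on the series, on what has been measured and on what is new or still open speak of the compounds shown alone.

Three measured compounds share one core and differ only in the aryl group on it. In an assay on CHO cells for displacement of a labelled ligand from adenosine receptor A3 (Homo sapiens), read by scintillation counting, tested at 10 uM (a higher number here means more inhibition at the concentration tested (going by the name of the read-out), a lower number less inhibition), compound 1 `CC(C)(C)Cc1c(-c2ccc(F)cc2)sc(N)c1C(=O)c1ccc(Cl)cc1` gives 9%. Compound 2 `CC(C)(C)Cc1c(-c2ccc(F)cc2F)sc(N)c1C(=O)c1ccc(Cl)cc1` gives 1% in this assay, and compound 3 `CC(C)(C)Cc1c(-c2ccc(Cl)c(Cl)c2)sc(N)c1C(=O)c1ccc(Cl)cc1` gives 1%. Compound 3 stands level with compound 2 at the digits shown, the two together being the lowest of the three numbers; its nearest neighbour is compound 2, with no change at the digits printed from compound 2 to compound 3 (within the scatter), and its furthest is compound 1, with a number 8 percentage points lower from compound 1 to compound 3 (within the scatter). Compound 4 `Cc1ccccc1-c1sc(N)c(C(=O)c2ccc(Cl)cc2)c1CC(C)(C)C` has not yet been measured and differs from compound 3 in one place: 2-methylphenyl in place of 3,4-dichlorophenyl on an aromatic carbon. Two measured steps exchange the aryl group at this same ring carbon, a number 8 percentage points lower from compound 1 to compound 3 (within the scatter) and no change at the digits printed from compound 2 to compound 3 (within the scatter), both within the scatter, as is a number 8 percentage points lower from compound 1 to compound 2 (within the scatter). No exchange of this group has so far moved the number beyond the scatter. Compound 4 is therefore expected to show a number 3 percentage points higher from compound 3 to compound 4 (within the scatter). In this assay compound 4 is estimated at 4%, between -8% and 16%.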

Compound 4, a percentage reported as inhibition, at one concentration (the size of the read-out at that concentration, not a potency): 1%
Estimate against measurement, compound 4: 3 percentage points above; the measured number falls inside the stated range.
By their numbers in this assay, from the lowest: compounds 2, 3, 4 and 1 (each within the scatter of the next).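

With 2-methylphenyl at this position, this assay shows no change at the digits printed from compound 3 to compound 4 (within the scatter) and no change at the digits printed from compound 2 to compound 4 (within the scatter) and a number 8 percentage points lower from compound 1 to compound 4 (within the scatter) for the same exchange. Compounds 1, 2 and 3 all carry halogens on this aryl group, whereas the 2-methylphenyl of compound 4 has only carbon atoms, so a group without halogen has now also left the number within the scatter. No measurement here gives a reason for this result.

The compounds shown leave open whether a phenyl group bearing a carboxylic acid or an amine, or a longer alkyl chain in place of the aryl group, would move the number beyond the scatter. They also leave open whether replacing the neopentyl group or the amino group on the shared core would do so.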